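Methylsulfanyl in Place of Hydrogen on the Aryl Ring

This account rests on a few compounds, and the source may have more. Where it says the series, first, only, none or still open, it means among the compounds named here.

Compound 1 `O=C(O)c1cnc(-c2ccccc2)[nH]c1=O` carries no substituent on its phenyl ring. In a functional assay on the whole organism (strain Sprague-Dawley) for inhibition, with Rattus norvegicus as the target, with a stated time of 10 min (on this read-out higher numbers stand for an effect only at larger amounts of compound and lower numbers for an effect already at smaller amounts), compound 1 gives 50 mg/kg, the highest number among the three compounds measured. Compound 2 `CCCCOc1ccccc1-c1ncc(C(=O)O)c(=O)[nH]1` gives 0.5 mg/kg, and compound 3 `O=C(O)c1cnc(-c2ccccc2OCc2ccccc2)[nH]c1=O` gives 5 mg/kg. Both measured steps away from compound 1 lower the number: a 100-fold lower number from compound 1 to compound 2 (2.00 log units; beyond the scatter) and a 10-fold lower number from compound 1 to compound 3 (1.00 log units; beyond the scatter). Between the two substituted compounds, a 10-fold higher number from compound 2 to compound 3 (1.00 log units; beyond the scatter).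

Compound 4 `CSc1ccccc1-c1ncc(C(=O)O)c(=O)[nH]1` differs from compound 1 by methylsulfanyl in place of hydrogen on an aromatic carbon. The two steps that enter a group at this same aromatic carbon bear on it, one large and one modest, and both go downward. The entering methylsulfanyl is a smaller group than either butoxy or benzyloxy, so a downward step of modest size is expected rather than the large one seen for compound 2. Compound 4 is therefore expected to give about 5 mg/kg, within the range 1 mg/kg to 25 mg/kg, which corresponds to an estimated 10-fold lower number from compound 1 to compound 4 (1.00 log units; beyond the scatter).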

Compound 4, dose for 50% inhibition: > 20 mg/kg
Compound 4: only a limit was reported; the forecaster's own chance of this, stated with the estimate: 5%; middle value at least 4.0-fold (0.60 log units) from the limit.
By their numbers in this assay, from the lowest: compound 2; then compound 3; then compound 1.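

Compound 4 is known only through a limit: the limit of > 20 mg/kg in this assay, at which 1 of the 4 values shown sits. Methylsulfanyl on this aromatic carbon, ortho to a large group, gives an at least 4.0-fold higher number from compound 3 to compound 4 (0.60 log units; beyond the scatter) and an at least 40-fold higher number from compound 2 to compound 4 (1.60 log units; beyond the scatter), so the low numbers of compound 2 and compound 3 do not follow from just any group entering at this place. On these data alone, the step from compound 1 to compound 4 cannot be read, so it remains unknown whether methylsulfanyl lowers the number at all compared with hydrogen.

The compounds shown leave open whether the gap to compound 2 follows from the oxygen linking the group to the ring or from the length of the chain. Butylsulfanyl would speak to the linking atom and methoxy to the chain, each differing in one place from a compound shown.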